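Swapping the naphthalene on sulfur for tert-butylphenyl

The source may report more compounds than this note shows. Statements on the series, on what has been measured and on what is new or still open speak of the compounds shown alone.

Compound 1 `Nc1ccccc1NC(=O)/C=C/c1ccc(CSc2ccc(F)cc2)cc1` gives 10.4%
Compound 2 `Nc1ccccc1NC(=O)/C=C/c1ccc(CSc2cccc3ccccc23)cc1` gives 22.1%

In a functional assay on HeLa cells (Homo sapiens) for inhibition, read by CCK-8 assay, with a stated time of 72 h, tested at 8 uM (a lower number here means less inhibition of growth, a higher number more inhibition of growth at the concentration tested), compound 2 stands highest of the two measured compounds at 22.1%, and compound 1 lies lower at 10.4%. The next case is compound 3 `CC(C)(C)c1ccc(SCc2ccc(/C=C/C(=O)Nc3ccccc3N)cc2)cc1`, not yet measured. Its change from compound 2 is 4-(tert-butyl)phenyl in place of naphthalen-1-yl on a sulfur, with 4-(tert-butyl)phenyl in place of naphthalen-1-yl on a sulfur.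

Among the measured compounds shown here, only one measured step bears on this change. It is the exchange at the same sulfur, a number 11.7 percentage points higher from compound 1 to compound 2 (beyond the scatter), a modest step beyond the scatter. Here naphthalen-1-yl replaced 4-fluorophenyl, so the new group in compound 3 returns to a substituted phenyl, though a different one. A single step cannot show how far a tert-butyl substituent departs from fluoro. A slight fall is expected in this assay because compound 1 with its substituted phenyl reads only 10.4%. The step of a number 4.1 percentage points lower from compound 2 to compound 3 (within the scatter) is expected to be small and downward, probably within the scatter. For compound 3 the estimate is 18%, with an expected range from 7% to 31%.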

Compound 3, percent growth inhibition at one concentration: 9.8%
The estimate for compound 3 lay 8.2 percentage points above the measured number; the range from low to high includes it.
By their numbers in this assay, from the lowest: compounds 3 and 1 (each within the scatter of the next); then compound 2.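

In this assay, among the compounds shown here, tert-butyl in place of fluoro on an aromatic carbon gives a number 0.6 percentage points lower from compound 1 to compound 3 (within the scatter), so these two substituted phenyl groups on the sulfur cannot be told apart, although the earlier compounds offered only one such group. The exchange of naphthalen-1-yl for 4-(tert-butyl)phenyl gives a number 12.3 percentage points lower from compound 2 to compound 3 (beyond the scatter). Both groups hold the same count of heavy atoms, all of them carbon, and the higher reading among these three compounds goes with the group of two aromatic rings and not with the heavy-atom count; neither of the other compounds goes against this, though three compounds make a narrow base. Nothing measured here accounts for this difference.

Going by these compounds, what remains open is whether the higher reading belongs to two aromatic rings in general or to naphthalen-1-yl alone, and whether an unsubstituted phenyl on the sulfur would read like the two substituted phenyl groups. On these data alone, it is also open whether an amine or a carboxylic acid on that phenyl ring would move the reading away from that of the fluoro and tert-butyl compounds.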